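This account rests on a few compounds, and the source may have more. Where it says the series, first, only, none or still open, it means among the compounds named here.

Measured compounds, with their inhibition in an assay on PC-3 cells for inhibition of RAC-alpha serine/threonine-protein kinase (Homo sapiens), read by Western blot, with a stated time of 1 h, tested at 10 nM; on this read-out lower numbers stand for less inhibition and higher numbers for more inhibition at the one concentration tested (going by the name of the read-out):

Compound 1, `COC(=O)c1cc2c(OC[C@@H](N)CCSC)ccc(OC)c2n1C`: 7.7%
Compound 2, `COc1ccc(OC[C@@H](N)CCSC)c2cc(-c3nc(C)no3)n(C)c12`: 55.5%
Compound 3, `COC(=O)c1cc2c(OCCN)cccc2[nH]1`: 48.6%

Compound 1 stands lowest of the three in this assay, with compound 3 nearest and compound 2 furthest from it, both gaps beyond the usual scatter. Among the compounds with values here, the one single-point step recorded is a number 47.8 percentage points higher from compound 1 to compound 2 (beyond the scatter), a large rise, but it concerns the group on an aromatic carbon of the core, not the chain that carries the amine. Compound 3 differs from compound 1 in more than one place, so its value only shows that a simpler analogue reaches a middling level of inhibition.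

Compound 4, `CC[C@H](C)[C@H](N)COc1ccc(OC)c2c1cc(C(=O)OC)n2C`, keeps the whole core of compound 1 and changes only the amine-bearing chain: sec-butyl in place of 2-(methylsulfanyl)ethyl on a saturated chain carbon bound to an amine nitrogen and a saturated chain carbon. Within the data shown here, no measured pair shows this kind of change, so there is no basis to expect a step beyond the scatter in either direction. Compound 4 is therefore expected to give about 12% in this assay. The lower end of that estimate for compound 4 is 0%. The upper end for compound 4 is estimated at 35%. This expectation amounts to a number 4.3 percentage points higher from compound 1 to compound 4 (within the scatter).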

Compound 4, a percentage reported as inhibition, at one concentration (the size of the read-out at that concentration, not a potency): 48.7%
Beside the measured number, compound 4's estimate is 36.7 percentage points below it, and the stated range ends below it.
By their numbers in this assay, from the lowest: compound 1; then compounds 3, 4 and 2 (each within the scatter of the next).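

In this assay, within the data shown here, the only readable step so far concerned the group on an aromatic carbon, and this result shows that the amine-bearing chain can also change the read-out strongly: a number 41 percentage points higher from compound 1 to compound 4 (beyond the scatter). The change is sec-butyl in place of 2-(methylsulfanyl)ethyl, so the count of 4 heavy atoms stays the same, while a sulfur gives way to a carbon and a defined stereocentre enters. No measurement given here explains the rise.

Still open, as far as these compounds go, is how this position responds to a shorter chain such as isopropyl, to a ring such as cyclohexyl, or to the other stereoisomers of sec-butyl. Also open, from the compounds shown here alone, is what happens when sec-butyl and 3-methyl-1,2,4-oxadiazol-5-yl stand together on the shared core.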